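A few compounds are considered here, and "the series" means these few. Any claim that something is new, unique, unknown or untested is made for them only; others in the source may bear on it.

Measured so far in an assay on cells for inhibition of MAP kinase-interacting serine/threonine-protein kinase 1 (Homo sapiens), read by mobility shift assay, with stated times of 10 min and 60 min, in the presence of a further agent that is not named here; on this read-out higher numbers stand for weaker inhibition and lower numbers for stronger inhibition:

- Compound 1 `NCCOc1cc(-c2cccnc2)ccc1C(N)=O` gives 820 nM.
- Compound 2 `CC(C)Oc1cc(-c2cncc(-c3c[nH]nc3C3CC3)c2)ccc1C(N)=O` gives 130 nM.
- Compound 3 `CC(C)Oc1cc(-c2cncc(-c3cnn(C)c3)c2)ccc1C(N)=O` gives 400 nM.

Among these three, compound 1 stands at the highest number, that is, it is the weakest inhibitor of the set; compound 3 is nearest to it and compound 2 furthest, both beyond the usual scatter.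

Compound 4 `NC(=O)c1ccc(-c2cccnc2)cc1OC1CCNC1` is the next compound to be measured. It differs from compound 1 in one place: pyrrolidin-3-yl in place of 2-aminoethyl on an oxygen on an aromatic ring. The 2-aminoethoxy side chain is thus replaced by a (pyrrolidin-3-yl)oxy group, keeping one hydrogen-bond donor and one acceptor but folding the chain into a ring.

Going by the values given here, the only measured step in this set, a 3.1-fold higher number from compound 2 to compound 3 (0.49 log units; beyond the scatter), concerns a different part of the molecule, the pyrazole attached to the pyridine, and so says nothing about the ether side chain. Among the compounds with values here, compounds 2 and 3 differ from compound 1 in more than one place, so no single step isolates the side chain either. With no direct guide, the expectation for compound 4 is a change that stays within the scatter, leaning neither clearly stronger nor weaker. Compound 4 is therefore expected to give 700 nM, within a range from 300 nM to 1600 nM. This estimate means a step of a 1.2-fold lower number from compound 1 to compound 4 (0.07 log units; within the scatter), expected to lie within the scatter.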

Compound 4, half-maximal inhibitory concentration: 1900 nM
Estimate against measurement, compound 4: 2.7-fold (0.43 log units) below; measured number above the stated range.
By their numbers in this assay, from the lowest: compound 2; then compound 3; then compound 1; then compound 4.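

In this assay, replacing the open chain with a ring on this oxygen gives a 2.3-fold higher number from compound 1 to compound 4 (0.36 log units; beyond the scatter), which means weaker inhibition. Going by these compounds alone, this is the first reading of the side chain with the rest of the molecule unchanged, and it shows that inhibition responds to the group on this oxygen even when the hydrogen-bond donor and acceptor counts and the net charge stay the same. Nothing available here gives a cause for this shift.

On these data alone, it remains open whether the ring itself or the larger group matters more, and a piperidin-4-yl group or a longer chain such as 3-aminopropyl on the same oxygen would help separate the two. As far as these compounds go, it also remains open whether this change would have a similar effect on the pyrazole-bearing compound 2 and compound 3.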